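Pyridin-2-yl to pyrimidin-2-yl on the piperazine nitrogen

The source may report more compounds than this note shows. Statements on the series, on what has been measured and on what is new or still open speak of the compounds shown alone.

Compound 1 `O=C(NCCCN1CCN(c2ccccn2)CC1)c1ccc2ccccc2c1` and compound 2 `O=C(NCCCN1CCN(c2ncccn2)CC1)c1ccc2ccccc2c1` share one core; compound 3 `O=C(NCCCN1CCN(c2ccccn2)CC1)c1ccc2ccccc2n1` and compound 4 `O=C(NCCCN1CCN(c2ncccn2)CC1)c1ccc2ccccc2n1` share another, and the difference between the two cores is not broken down here. Compound 2 differs from compound 1 in one place: pyrimidin-2-yl in place of pyridin-2-yl on an amine nitrogen in a ring. Compound 4 differs from compound 3 by the same change: pyrimidin-2-yl in place of pyridin-2-yl on an amine nitrogen in a ring.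

In an assay on HEK293 cells for inhibition of sodium-dependent dopamine transporter (Homo sapiens), read by scintillation counting (on this read-out higher numbers stand for weaker inhibition and lower numbers for stronger inhibition), compound 1 gives only a limit of the assay, > 10000 nM. In this assay compound 2 likewise gives a limit, > 10000 nM. Compound 3 gives a limit in this assay as well, > 10000 nM. For the measured compounds named here, for the one measured pair the change gives a step that the two limits leave unreadable from compound 1 to compound 2 because the limit of > 10000 nM in this assay, at which 3 of the 3 values shown sit, is where both values rest, so no number for the size of the step can be read from it.

Compound 4 is not yet measured in this assay. Going by the values given here, since the change that leads to it is the same as the one from compound 1 to compound 2, and since compound 3 itself sits at a limit, compound 4 is expected to remain at the limit too. Compound 4 is estimated at 20000 nM in this assay, with a range from 8000 nM to 60000 nM. This estimated step that the limit leaves unreadable from compound 3 to compound 4 rests on the limit of > 10000 nM in this assay, at which 3 of the 3 values shown sit, and on nothing else, so it carries little weight.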

Compound 4, half-maximal inhibitory concentration: > 10000 nM
Compound 4 gave a limit, no number; the forecaster's own chance of this, stated with the estimate: 85%; the middle value is on the limit's open side.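

In this assay compound 4 gives > 10000 nM, which is a limit of the assay and not a number. No size can be read for the step from compound 3 to compound 4, because both values rest on a limit: the limit of > 10000 nM in this assay, at which 4 of the 4 values shown sit.

The compounds shown leave open whether pyrimidin-2-yl in place of pyridin-2-yl changes the read-out in this assay at all.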